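Dithiocarbonate Ketones: Adding a Second Methoxy Group

The source may report more compounds than this note shows. Statements on the series, on what has been measured and on what is new or still open speak of the compounds shown alone.

The measured compounds:
compound 1, `CCSC(=S)SCC(=O)c1ccc(C)cc1`, gives 3980 nM in a functional assay on HeLa cells (Homo sapiens) for antiproliferative activity, read by resazurin assay; on this read-out lower numbers stand for stronger inhibition and higher numbers for weaker inhibition;
compound 2, `CCSC(=S)SCC(=O)c1ccc(OC)c(OC)c1`, gives 5010 nM in this assay;
compound 3, `CCSC(=S)SCC(=O)c1ccc(OC)cc1`, gives 2510 nM in this assay.

Compound 3 stands together with compounds 1 and 2: the step of a 1.6-fold lower number from compound 1 to compound 3 (0.20 log units; within the scatter) and the step of a 2.0-fold lower number from compound 2 to compound 3 (0.30 log units; within the scatter) both lie within the scatter, so no order among the three can be claimed.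

Compound 4, `CCSC(=S)SCC(=O)c1ccc(OC)cc1OC`, is not yet measured. It differs from compound 3 by methoxy in place of hydrogen on an aromatic carbon, the methoxy entering at the place ortho to a group of 9 heavy atoms and meta to a methoxy group.

Among the compounds with values here, only the step from compound 2 to compound 3 bears on this change, since compound 2 also carries a methoxy group in addition to the one of compound 3, and that step was within the scatter. Compound 4 is therefore expected to show a step of a 1.4-fold higher number from compound 3 to compound 4 (0.14 log units; within the scatter), that is, none beyond the scatter. Compound 4 is estimated at 3500 nM, between 1400 nM and 9000 nM.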

Compound 4, half-maximal inhibitory concentration: 12600 nM
Beside the measured number, compound 4's estimate is 3.6-fold (0.56 log units) below it, and the stated range ends below it.
By their numbers in this assay, from the lowest: compounds 3, 1 and 2 (each within the scatter of the next); then compound 4.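

Methoxy in place of hydrogen, ortho to a group of 9 heavy atoms and meta to a methoxy group, gives a 5.0-fold higher number from compound 3 to compound 4 (0.70 log units; beyond the scatter) in this assay, the first step among these compounds that lies beyond the scatter. Within the data shown here, the earlier step involving a second methoxy, a 2.0-fold lower number from compound 2 to compound 3 (0.30 log units; within the scatter), stayed within the scatter, so a second methoxy on the ring does not carry the same consequence at every place, and this place is the one where a weaker number shows clearly. No measurement offered here accounts for that difference between the two places.

The compounds shown leave open whether the rise belongs to methoxy itself or to any group entering at this place. A fluorine atom, a hydroxyl or an amine there could separate those two readings in this assay.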